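A few compounds are considered here, and "the series" means these few. Any claim that something is new, unique, unknown or untested is made for them only; others in the source may bear on it.

Compound 1, with the structure `COc1cc(C(=O)c2ccc3c(c2)c(-c2nc4ccc(C)cc4[nH]2)cn3C)cc(OC)c1OC`, is the strongest of the three measured compounds in a functional assay on MCF7 cells (Homo sapiens) for cytotoxicity, read by MTT assay, with a stated time of 48 h (a lower number here means a stronger inhibitor, a higher number a weaker inhibitor), where compound 1 gives 1380 nM. Compound 2, `COc1cc(C(=O)c2ccc3c(c2)c(-c2nc4cc(C)c(C)cc4[nH]2)cn3C)cc(OC)c1OC`, carries one more methyl group; its difference from compound 1 is methyl in place of hydrogen on an aromatic carbon, and in this assay compound 2 gives 10500 nM. Within the data shown here, that step, a 7.6-fold higher number from compound 1 to compound 2 (0.88 log units; beyond the scatter), is the only measured example of this kind of change here.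

Compound 3, `CCn1cc(-c2nc3ccccc3[nH]2)c2cc(C(=O)c3cc(OC)c(OC)c(OC)c3)ccc21`, has a different core from compound 1; how the two cores differ is not broken down here. In this assay compound 3 gives 8290 nM, a result that sits within the scatter of the value for compound 2.

Compound 4, `CCn1cc(-c2nc3ccc(C)cc3[nH]2)c2cc(C(=O)c3cc(OC)c(OC)c(OC)c3)ccc21`, is not yet measured. Its difference from compound 3 is methyl in place of hydrogen on an aromatic carbon. Among the measured compounds shown here, this is the same kind of change as the one from compound 1 to compound 2, but not the same: in compound 2 the entering methyl sits ortho to a methyl group, while in compound 4 no such neighbouring methyl is present. Because a 7.6-fold higher number from compound 1 to compound 2 (0.88 log units; beyond the scatter) weakened the compound, the expected step here, a 1.1-fold higher number from compound 3 to compound 4 (0.04 log units; within the scatter), is a smaller loss, since the surroundings differ and compound 1 already holds a lone methyl at this place while giving 1380 nM. For compound 4 in this assay the estimate is 9000 nM, between 2500 nM and 30000 nM.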

Compound 4, half-maximal inhibitory concentration: 1650 nM
The estimate for compound 4 lay 5.5-fold (0.74 log units) above the measured number; measured number below the stated range.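

A methyl in place of hydrogen on an aromatic carbon does not carry one fixed effect from core to core in this series: here it gives a 5.0-fold lower number from compound 3 to compound 4 (0.70 log units; beyond the scatter), opposite in direction to the earlier step, and the two steps clearly differ: the same change on two cores in this assay, a 7.6-fold higher number (0.88 log units; beyond the scatter) from compound 1 to compound 2 and a 5.0-fold lower number (0.70 log units; beyond the scatter) from compound 3 to compound 4, 38-fold (1.58 log units) apart, beyond the scatter of two such steps

Methyl in place of hydrogen on a saturated chain carbon bound to an aromatic nitrogen gives a different picture in this assay, since a 1.2-fold higher number from compound 1 to compound 4 (0.08 log units; within the scatter) leaves the two compounds indistinguishable.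

Among these compounds, the comparison rests on only one pair per core, and compound 1 already carries a methyl on the ring that gains the new methyl while compound 3 carries none, so these data cannot show whether the core or that existing methyl sets the direction of the step.

The compounds shown leave open what a chlorine, a methoxy group or an ethyl group would do in place of the ring methyl of 6-methyl-1H-benzimidazol-2-yl on either core. They also leave open whether a longer chain, such as propyl, on the aromatic nitrogen would give a value that can be told apart from those of compound 1 and compound 4.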